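This account rests on a few compounds, and the source may have more. Where it says the series, first, only, none or still open, it means among the compounds named here.

Measured compounds:
Compound 1 `O=C(Nc1cccc(-n2cc(-c3ccncc3)c(-c3ccc(Cl)c(O)c3)n2)c1)Nc1cccc(C(F)(F)F)c1`: 7650 nM
Compound 2 `COc1cc(-c2nn(-c3cccc(NC(=O)c4cccc(C(F)(F)F)c4)c3)cc2-c2ccncc2)ccc1Cl`: > 50000 nM
Compound 3 `COc1cc(-c2nn(-c3cccc(NC(=O)Nc4ccc(Cl)c(Cl)c4)c3)cc2-c2ccncc2)ccc1Cl`: 2470 nM

All three were tested in a functional assay on U-251 cells (Homo sapiens) for inhibition, read by sulforhodamine B assay, with a stated time of 48 h; a higher number here means a weaker inhibitor of growth, a lower number a stronger inhibitor of growth. Compound 2 gave only a limit in this assay, > 50000 nM, with no exact number, as noted in the limit of > 50000 nM in this assay, at which 1 of the 3 values shown sits. Among the two exact numbers, compound 3 stands lowest, and compound 1 sits a step higher at 7650 nM.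

Going by the values given here, the only measured one-point step is an at least 20-fold lower number from compound 2 to compound 3 (1.30 log units; beyond the scatter), which swaps an amide tail for a urea tail and is large.

Compound 4 `COc1cc(-c2nn(-c3cccc(NC(=O)Nc4cccc(C(F)(F)F)c4)c3)cc2-c2ccncc2)ccc1Cl` is not yet measured. It differs from compound 3 as follows: 3-(trifluoromethyl)phenyl in place of 3,4-dichlorophenyl on an amide-type nitrogen. This change keeps the urea and only alters the aryl group on it, so the large measured step does not directly predict it. Compound 1 carries the same trifluoromethylphenyl urea with a different group on the shared core and gives 7650 nM, a higher number than compound 3. Compound 4 is therefore expected to show a modest rise, a 2.0-fold higher number from compound 3 to compound 4 (0.31 log units; beyond the scatter), and its estimated value in this assay is 5000 nM, with a likely range from 1500 nM to 16000 nM.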

Compound 4, concentration for total growth inhibition: 1370 nM
For compound 4 the middle estimate is 3.6-fold (0.56 log units) above the measured one; the measured number lies below the stated range.
By their numbers in this assay, from the lowest: compounds 4 and 3 (each within the scatter of the next); then compound 1. At a limit, above all of these: compound 2.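

In this assay, putting 3-(trifluoromethyl)phenyl in place of 3,4-dichlorophenyl on the amide-type nitrogen of the urea gives a 1.8-fold lower number from compound 3 to compound 4 (0.26 log units; within the scatter), so with this shared core the two aryl groups cannot be told apart at this position. With the 3-(trifluoromethyl)phenyl group now matched, the urea tail can be set directly against the amide tail, giving an at least 36-fold lower number from compound 2 to compound 4 (1.56 log units; beyond the scatter), while methyl in place of hydrogen on the oxygen on the aromatic ring gives a 5.6-fold lower number from compound 1 to compound 4 (0.75 log units; beyond the scatter), so this urea also responds to a change elsewhere on the core. The number for compound 2 is a limit and not an exact value: the limit of > 50000 nM in this assay, at which 1 of the 4 values shown sits.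

The compounds shown leave open whether a plain phenyl, or a phenyl carrying an amine or a carboxylic acid, would fit on this nitrogen. They also leave open whether an ethyl group on that oxygen would serve as well as methyl.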